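This account rests on a few compounds, and the source may have more. Where it says the series, first, only, none or still open, it means among the compounds named here.

Measured so far in a functional assay for antagonist activity at transient receptor potential cation channel subfamily V member 1 (Rattus norvegicus), read by FLIPR; a lower number here means a less potent compound, a higher number a more potent compound, by a factor of ten per unit of this negative logarithm:
- compound 1 `Cc1cccc(N2CC[C@H](NC(=O)Nc3ccccc3Br)C2)c1`: < 6.8
- compound 2 `O=C(Nc1ccccc1Br)N[C@@H]1CCN(c2ncccc2C(F)(F)F)C1`: 7.1

Compound 1 stands only as a limit: the value < 6.8 marks the edge of what this assay reports, not a number, so its true potency is somewhere at or under that edge (the limit of < 6.8 in this assay, at which 1 of the 2 values shown sits). Among the compounds with values here, compound 2, with the trifluoromethyl-bearing pyridine in place of the tolyl group, reaches 7.1 in this assay; no step is computed between compound 1 and compound 2, so the two values are simply set side by side.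

Compound 3 `Cc1cccc(N2CC[C@@H](NC(=O)Nc3ccccc3Br)C2)c1` is the next entry. It differs from compound 1 as follows: the two compounds have the same atoms and bonds and differ only in configuration as drawn: 1 of 1 stereo elements differ; a stereocentre at a saturated ring carbon is drawn S in compound 1 and R in compound 3. With a single stereocentre in the series and compound 1 sitting at the limit, the drawn R configuration is the open question. Within the data shown here, no measured pair shows the size such an inversion brings, so the expectation rests on the limit of compound 1 alone: the step of a number at least 0.40 log units higher from compound 1 to compound 3 (beyond the scatter) is expected to go upward, past the usual scatter, but with wide uncertainty. Compound 3 is accordingly estimated at 7.2 in this assay, within 6.3 to 8.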

Compound 3, negative logarithm of the antagonist equilibrium constant: 7.7
The estimate for compound 3 lay 0.50 log units below the measured number; measured number inside the range.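

In this assay, within the data shown here, the change from S to R at the saturated ring carbon gives a number at least 0.90 log units higher from compound 1 to compound 3 (beyond the scatter), the first measured pair to show that the configuration at this position matters with the atoms and bonds held constant. The value of compound 1, < 6.8, is a limit of the assay and not a number. The change in potency can be put on this one stereocentre, and on no other part of the structure, because nothing else separates the two compounds: the fact that compounds 1 and 3 differ only in the configuration as drawn

The compounds shown leave open whether the same preference at this carbon holds with the trifluoromethyl-bearing pyridine of compound 2, since a single pair with the tolyl group cannot carry the finding over to another ring. Also open, on these data alone, is how far the R series tolerates change elsewhere on the shared core, for instance a methoxy group or an amine in place of the bromine.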